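A few compounds are considered here, and "the series" means these few. Any claim that something is new, unique, unknown or untested is made for them only; others in the source may bear on it.

Measured so far in a functional assay on HeLa cells (Homo sapiens) for cytotoxicity, read by MTT assay, with a stated time of 48 h; a lower number here means a stronger inhibitor, a higher number a weaker inhibitor:
- compound 1, `COc1cc(/C=C/C(=O)C2=C(/C=C/c3ccc(O)c(OC)c3)NC(=O)NC2c2ccccc2O)ccc1O`, gives 50000 nM
- compound 2, `COc1cc(/C=C/C(=O)C2=C(/C=C/c3ccc(O)c(OC)c3)NC(=O)NC2c2ccc(N(C)C)cc2)ccc1O`, gives 25000 nM
- compound 3, `COc1cc(/C=C/C(=O)C2=C(/C=C/c3ccc(O)c(OC)c3)NC(=S)NC2c2ccccc2O)ccc1O`, gives 25000 nM

Within the pair sharing the core of compound 1, the change 4-(dimethylamino)phenyl in place of 2-hydroxyphenyl on a saturated ring carbon made a step of a 2.0-fold lower number from compound 1 to compound 2 (0.30 log units; within the scatter). Compound 3 carries a different core from compound 1; the difference between the two cores is not broken down here. Compound 3 and compound 2 stand level in this assay at the digits given, and compound 3 sits a little under compound 1, though the gap stays inside the usual scatter, so no order among the three can be claimed.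

Compound 4, `COc1cc(/C=C/C(=O)C2=C(/C=C/c3ccc(O)c(OC)c3)NC(=S)NC2c2ccc(N(C)C)cc2)ccc1O`, is not yet measured. It differs from compound 3 by 4-(dimethylamino)phenyl in place of 2-hydroxyphenyl on a saturated ring carbon, and the place of the change reads the same as for the earlier pair, so this is the same change carried onto the core of compound 3. Among the measured compounds shown here, the step from compound 3 to compound 4 in this assay is expected to be about a 1.7-fold lower number from compound 3 to compound 4 (0.22 log units; within the scatter), set beside a 2.0-fold lower number from compound 1 to compound 2 (0.30 log units; within the scatter), because compound 3 starts from 25000 nM and only one earlier instance of this change, itself within the scatter, is available. Compound 4 is accordingly estimated at 15000 nM, with a range from 6000 nM to 40000 nM.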

Compound 4, half-maximal inhibitory concentration: 12500 nM
For compound 4 the middle estimate is 1.2-fold (0.08 log units) above the measured one; measured number inside the range.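

Carried onto the second core, 4-(dimethylamino)phenyl in place of 2-hydroxyphenyl on a saturated ring carbon makes a 2.0-fold lower number from compound 3 to compound 4 (0.30 log units; within the scatter) in this assay. The change reads the same on the two cores: the same change on two cores in this assay, a 2.0-fold lower number (0.30 log units; within the scatter) from compound 1 to compound 2 and a 2.0-fold lower number (0.30 log units; within the scatter) from compound 3 to compound 4, 1.0-fold (0.00 log units) apart, within the scatter of two such steps. This agreement shows no sign that the core alters the step, but each step lies within the scatter, so it does not show that the change has a real effect on the number, and two cores are too few to set a rule for the series.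

The compounds shown leave open whether a different group on that saturated ring carbon, such as a carboxylic acid, a nitrile or a phenyl ring bearing a longer chain, would give a step beyond the scatter. They also leave open whether the same holds on a core in which the 2-(4-hydroxy-3-methoxyphenyl)ethenyl group gives way to another group, such as a plain methyl.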